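Tertiary amine variant of compound 1 on the chain terminus

The source may report more compounds than this note shows. Statements on the series, on what has been measured and on what is new or still open speak of the compounds shown alone.

Compound 1 `NCCCCN(C[C@H]1Cc2ncccc2CN1)[C@H]1CCCc2cccnc21` gives 64% in an ADME assay on microsomes from liver (Rattus norvegicus) for metabolic stability, using NADPH, with a stated time of 10 min (on this read-out higher numbers stand for a more stable compound and lower numbers for a less stable compound), the highest of the three values shown. Compound 2 `NCCCCN(C[C@H]1Cc2nccnc2CN1)[C@H]1CCCc2cccnc21` gives 50%, and compound 3 `NC(=O)NCCCCN(C[C@H]1Cc2ncccc2CN1)[C@H]1CCCc2cccnc21` gives 1%. Among the compounds with values here, the one measured step that changes the chain terminus, a number 63 percentage points lower from compound 1 to compound 3 (beyond the scatter), is large. Compound 4 `CN(C)CCCCN(C[C@H]1Cc2ncccc2CN1)[C@H]1CCCc2cccnc21` differs from compound 1 only at that terminus: dimethylamino in place of amino on a saturated chain carbon, four bonds along the chain from an amine nitrogen. Within the data shown here, no measured step shows dimethylamino in place of amino, so the change remains unmeasured; the only guide is that substitution on that nitrogen in compound 3 1% cost heavily. The step for compound 4 is therefore expected to be downward, a number 22 percentage points lower from compound 1 to compound 4 (beyond the scatter), with wide uncertainty. Compound 4 is estimated at 42%, within 15% to 68%.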

Compound 4, percent of the compound remaining: 27%
Compound 4: the middle estimate sits 15 percentage points above what was measured; the range from low to high includes it.
By their numbers in this assay, from the lowest: compound 3; then compound 4; then compound 2; then compound 1.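

In this assay dimethylamino in place of amino gives a number 37 percentage points lower from compound 1 to compound 4 (beyond the scatter) and so shows that the terminal amino group is not replaced freely: a second, non-ureido replacement also goes with a large fall. Dimethylamino in place of ureido gives a number 26 percentage points higher from compound 3 to compound 4 (beyond the scatter) and so orders these termini, with the ureido compound lowest. No supporting evidence bears on either step.

Open, as far as these compounds go, is whether a single methyl on that nitrogen, as a methylamino terminus, gives a smaller fall. Also open, from the compounds shown here alone, is how a longer chain carrying the amino group would compare.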